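Swapping methyl for chloro on the sulfamoylphenyl ring

The source may report more compounds than this note shows. Statements on the series, on what has been measured and on what is new or still open speak of the compounds shown alone.

Compound 2 `CCCS(=O)(=O)Nc1ccc(F)c(C(=O)c2n[nH]c3ncc(-c4ccc(S(N)(=O)=O)cc4C)cc23)c1F` belongs to a small set of two measured analogues sharing one core. In an assay for binding affinity to dual specificity mitogen-activated protein kinase kinase 4 (Homo sapiens), read by KINOMEscan, tested at 10 nM (a lower number here means a stronger effect, a higher number a weaker effect of the compound at the concentration tested), compound 1 `CCCS(=O)(=O)Nc1ccc(F)c(C(=O)c2n[nH]c3ncc(-c4ccc(S(N)(=O)=O)cc4)cc23)c1F` gives 5.1%, while compound 2 gives 24%, the higher of the two numbers and therefore the weaker effect. Among the compounds with values here, the one measured step, a number 18.9 percentage points higher from compound 1 to compound 2 (beyond the scatter), is a methyl in place of hydrogen on an aromatic carbon.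

Compound 3 `CCCS(=O)(=O)Nc1ccc(F)c(C(=O)c2n[nH]c3ncc(-c4ccc(S(N)(=O)=O)cc4Cl)cc23)c1F` is not yet measured. It differs from compound 2 by chloro in place of methyl on an aromatic carbon. Within the data shown here, no measured step matches this exchange directly: the only step known concerns the methyl entering in place of hydrogen, and it was modest in size. Since chloro and methyl are each a single heavy atom placed on the same aromatic carbon, the step is expected to be small, most likely within the scatter, with no direction strongly favoured, so the estimated step is a number 2 percentage points lower from compound 2 to compound 3 (within the scatter).

For compound 3 the estimate in this assay is 22%, with a range from 8% to 45%.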

Compound 3, a percentage reported as activity, at one concentration (the size of the read-out at that concentration, not a potency): 23%
Compound 3: middle estimate off by 1 percentage points, on the low side; measured number inside the range.
By their numbers in this assay, from the lowest: compound 1; then compounds 3 and 2 (each within the scatter of the next).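

In this assay, chloro in place of methyl on this aromatic carbon gives a number 1 percentage points lower from compound 2 to compound 3 (within the scatter), so the assay does not separate these two groups at this position. Chloro in place of hydrogen gives a number 17.9 percentage points higher from compound 1 to compound 3 (beyond the scatter), a modest step that matches a number 18.9 percentage points higher from compound 1 to compound 2 (beyond the scatter) in printed size, which shows that the weaker effect relative to compound 1 is not peculiar to methyl but is shared by the two substituents compared here. No measurement available here explains why either group gives a weaker effect than hydrogen at this position.

On these data alone, it remains open whether a fluoro, a methoxy, an amine or a carboxylic acid on the same aromatic carbon would stay with compound 2 and compound 3 or return towards compound 1 at 5.1%, and thus whether any substituent here can match hydrogen. These numbers come from a single concentration, so they show only the stronger or weaker effect at that concentration and leave open how compound 1, compound 2 and compound 3 would compare at any other.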